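This account rests on a few compounds, and the source may have more. Where it says the series, first, only, none or still open, it means among the compounds named here.

The measured compounds:
Compound 1, `CC(C)=CC[C@@H](OC(=O)C1CCCCO1)C1=CC(=O)c2c(O)ccc(O)c2C1=O`: in a functional assay on HeLa cells (Homo sapiens) for cytotoxicity, read by MTT assay (on this read-out higher numbers stand for weaker inhibition and lower numbers for stronger inhibition), compound 1 gives > 100000 nM, which is a limit of the assay and not a number.
Compound 2, `CCC(CO[C@H](CC=C(C)C)C1=CC(=O)c2c(O)ccc(O)c2C1=O)OC(C)=O`: compound 2 gives 44000 nM.
Compound 3, `CC(C)=CC[C@@H](OCCO)C1=CC(=O)c2c(O)ccc(O)c2C1=O`: compound 3 gives 18600 nM.

Compound 1 stands at the limit of > 100000 nM in this assay, at which 1 of the 3 values shown sits, so for compound 1 only a limit is known, while compound 2 and compound 3 give numbers. The step of an at least 2.2-fold lower number from compound 1 to compound 2 (0.35 log units; beyond the scatter) and the step of an at least 5.3-fold lower number from compound 1 to compound 3 (0.73 log units; beyond the scatter) both exchange the whole (oxan-2-yl)carbonyl group on the oxygen of compound 1 for an ether chain; the step of a 2.4-fold lower number from compound 2 to compound 3 (0.37 log units; beyond the scatter) then changes that chain further.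

Compound 4, `CCCCCCC(C)(O)CC(=O)O[C@H](CC=C(C)C)C1=CC(=O)c2c(O)ccc(O)c2C1=O`, keeps the ester of compound 1 and differs from it only on the carbonyl carbon: 2-hydroxy-2-methyloctyl in place of oxan-2-yl on a carbonyl carbon. Within the data shown here, no measured step alters the acyl part while keeping the ester, so none of the three steps bears directly on this change. The steps from compound 1 to compound 2 and to compound 3 show that removing the ester brings the number down; compound 4 does not remove it. The account therefore expects compound 4 to remain close to compound 1, with a step of about an at least 1.2-fold lower number from compound 1 to compound 4 (0.09 log units; that floor lies within the scatter). Compound 4 is expected to give roughly 80000 nM, between 20000 nM and 300000 nM, with a fair chance that this assay again reports only a limit.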

Compound 4, half-maximal inhibitory concentration: > 100000 nM
Compound 4 gave a limit, no number; the forecaster's own chance of this, stated with the estimate: 50%; middle value at least 1.2-fold (0.09 log units) away from the limit.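

Compound 4 gives > 100000 nM, which is a limit of the assay and not a number. Compound 1 sits at the same limit, so no step between compound 1 and compound 4 can be read: the limit of > 100000 nM in this assay, at which 2 of the 4 values shown sit.

The compounds shown leave open whether 2-hydroxy-2-methyloctyl in place of oxan-2-yl on the carbonyl carbon changes the number at all.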